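Working notes: from compound 3 to compound 4

A few compounds are considered here, and "the series" means these few. Any claim that something is new, unique, unknown or untested is made for them only; others in the source may bear on it.

Measured in an ADME assay on MT4 cells (Homo sapiens) for cytotoxicity (on this read-out lower numbers stand for higher toxicity in this test and higher numbers for lower toxicity in this test), so far
compound 1 `COC(=O)N[C@H](C(=O)NN(CCC[C@@](O)(Cc1ccccc1)C(=O)N[C@H]1c2ccccc2C[C@H]1O)Cc1ccccc1)C(C)(C)C` gives > 10000 nM as a limit
compound 2 `COC(=O)N[C@H](C(=O)NN(CCC[C@@](O)(Cc1ccccc1)C(=O)N[C@H]1c2ccccc2C[C@H]1O)Cc1ccc(F)cc1)C(C)(C)C` gives > 10000 nM as a limit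
compound 3 `COC(=O)N[C@H](C(=O)NN(CCC[C@@](O)(Cc1ccccc1)C(=O)N[C@H]1c2ccccc2C[C@H]1O)CC(C)C)C(C)(C)C` gives > 10000 nM as a limit

Compound 3 stands at the limit of > 10000 nM in this assay, at which 3 of the 3 values shown sit, and has no number of its own. Compound 4 `COC(=O)N[C@H](C(=O)NN(CCC[C@@](O)(Cc1ccccc1)C(=O)N[C@H]1c2ccccc2C[C@H]1O)Cc1ccc(-c2cncnc2)cc1)C(C)(C)C` carries 4-(pyrimidin-5-yl)phenyl in place of isopropyl on a saturated chain carbon bound to an amine nitrogen. For the measured compounds named here, two measured steps touch this place, a step that the two limits leave unreadable from compound 1 to compound 3 and a step that the two limits leave unreadable from compound 2 to compound 3 and neither has a readable size. Phenyl in compound 1 and 4-fluorophenyl in compound 2 both leave the read-out at the limit of > 10000 nM in this assay, at which 3 of the 3 values shown sit, as well. The expected change is therefore none beyond the scatter, in either direction, estimated as a step that the limit leaves unreadable from compound 3 to compound 4 in this assay for now. Compound 4 is estimated at 12000 nM with a range of 6000 nM to 30000 nM. Compound 4 may again give only a limit.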

Compound 4, half-maximal cytotoxic concentration: > 10000 nM
Compound 4: no number, only a limit; the forecaster's own chance of this, stated with the estimate: 80%; the middle value lies beyond the limit too.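

In this assay, for the compounds shown here, compound 4 gives > 10000 nM, a limit and not a number, so no step from compound 4 to compound 1, compound 2 or compound 3 can be read. The compounds shown leave open where the half-maximal cytotoxic concentration of any of them lies.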